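Swapping cyano for nitro on the aryl piperazine

The compounds below may be only part of what the source reports. "The series", "measured", "known", "first", "only" and "open" are said of these compounds alone.

Within the data shown here, in an assay on isolated protein for inhibition of lysosomal alpha-glucosidase (Homo sapiens), read by fluorescence, with stated times of 5 min and 45 min (on this read-out lower numbers stand for stronger inhibition and higher numbers for weaker inhibition), compound 2 `N#Cc1ccc(N2CCN(S(=O)(=O)c3ccc4c(c3)CC(=O)N4)CC2)cc1` gives 3260 nM, the higher of the two numbers so far, though within the scatter of compound 1 `O=C1Cc2cc(S(=O)(=O)N3CCN(c4ccc(O)cc4)CC3)ccc2N1`, which gives 2370 nM in this assay. Among the measured compounds shown here, the one measured step, a 1.4-fold higher number from compound 1 to compound 2 (0.14 log units; within the scatter), stayed within the scatter. Compound 3 `O=C1Cc2cc(S(=O)(=O)N3CCN(c4ccc([N+](=O)[O-])cc4)CC3)ccc2N1` differs from compound 2 in one place: nitro in place of cyano on an aromatic carbon. For the measured compounds named here, that single step is the only guide, and it suggests no movement beyond the scatter. The expected step is a 1.0-fold lower number from compound 2 to compound 3 (0.01 log units; within the scatter). Compound 3 is therefore estimated at 3200 nM, with a range from 1400 nM to 7500 nM.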

Compound 3, half-maximal inhibitory concentration: 3260 nM
Estimate against measurement, compound 3: 1.0-fold (0.01 log units) below; the measured number falls inside the stated range.
By their numbers in this assay, from the lowest: compounds 1, 2 and 3 (each within the scatter of the next).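

In this assay, nitro at this position, para to a large group, reads like the two groups before it (no change at the digits printed from compound 2 to compound 3 (within the scatter); a 1.4-fold higher number from compound 1 to compound 3 (0.14 log units; within the scatter)). Hydroxy, cyano and nitro therefore all lie within the scatter of one another, so exchanging one for another on this ring shows no measurable effect on the number. No measured evidence here bears on this result. Still open, going by these compounds, is whether an amine or a carboxylic acid at this position would also stay within the scatter. A change elsewhere on the shared core is equally untested by these compounds.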